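The source may report more compounds than this note shows. Statements on the series, on what has been measured and on what is new or still open speak of the compounds shown alone.

Measured so far:
- compound 1, `Cc1cc(C)cc(CC(C(=O)O)[C@H](N)C(=O)O)c1`: 36%
- compound 2, `Cc1cccc(CC(C(=O)O)[C@H](N)C(=O)O)c1`: 33%

In an in vitro assay on cells for inhibition of excitatory amino acid transporter 3 (Homo sapiens), tested at 100 uM (on this read-out higher numbers stand for more inhibition at the one concentration tested (going by the name of the read-out) and lower numbers for less inhibition), compound 2 gives 33% and stands lowest of the two measured numbers; the nearest is compound 1, which in this assay gives 36%, a gap that lies within the scatter, so the two are not distinguished.

Compound 3, `N[C@H](C(=O)O)C(Cc1cccc(F)c1)C(=O)O`, has not been measured. It differs from compound 2 by fluoro in place of methyl on an aromatic carbon.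

Within the data shown here, the only step that bears on this position is a number 3 percentage points lower from compound 1 to compound 2 (within the scatter), where hydrogen replaced methyl on the same aromatic carbon and the read-out stayed within the scatter. That step suggests the methyl itself contributes little to inhibition at the concentration tested. Nothing is known here for fluoro at this position, so the expectation rests on that single step and on the value of compound 2.

For compound 3 a value of 31% is estimated, with a range from 16% to 46%. The step this estimate means, a number 2 percentage points lower from compound 2 to compound 3 (within the scatter), is expected to lie within the scatter, with no direction beyond it.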

Compound 3, a percentage reported as inhibition, at one concentration (the size of the read-out at that concentration, not a potency): 0%
The estimate for compound 3 lay 31 percentage points above the measured number; the measured number lies below the stated range.
By their numbers in this assay, from the lowest: compound 3; then compounds 2 and 1 (each within the scatter of the next).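

The result shows that this aromatic carbon, meta to a large group, is not indifferent to its substituent in this assay: fluoro in place of methyl gives a number 33 percentage points lower from compound 2 to compound 3 (beyond the scatter). The earlier step, a number 3 percentage points lower from compound 1 to compound 2 (within the scatter), left one methyl in place and so could not show this; here, one heavy atom replaces another with no change in the counted donors, acceptors or net charge, and compound 3 gives 0%. No measurement shown here accounts for this loss of inhibition.

It remains open whether the step reflects the methyl leaving or the fluoro entering, since the compounds shown include no partner with hydrogen alone at this carbon. On these data alone, how chloro, methoxy or a longer alkyl chain at this carbon would read in this assay also remains open.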